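Swapping the benzyl ring in a nitroquinoxaline cytotoxicity series

The compounds below may be only part of what the source reports. "The series", "measured", "known", "first", "only" and "open" are said of these compounds alone.

Measured so far:
Compound 1 `CN1CCN(CCCNc2nc3cc([N+](=O)[O-])ccc3nc2NCc2ccc(C(F)(F)F)cc2)CC1` — in an ADME assay on HEK293 cells (Homo sapiens) for cytotoxicity, read by MTT assay, with a stated time of 24 h (a higher number here means a weaker inhibitor, a lower number a stronger inhibitor), compound 1 gives 9.53 ug/mL.
Compound 2 `O=[N+]([O-])c1ccc2nc(NCc3ccc(C(F)(F)F)cc3)c(N3CCCCC3)nc2c1` — compound 2 gives > 200 ug/mL, which is a limit of the assay rather than a number.
Compound 3 `CN(C)CCCNc1nc2cc([N+](=O)[O-])ccc2nc1NCc1ccc(F)cc1` — compound 3 gives 4.28 ug/mL.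

Among the two numbers that are not limits, compound 3 gives the lowest, so it is the strongest inhibitor here, and compound 1 sits next to it with a gap beyond the scatter. Compound 1 and compound 3 differ in two places, so their two values can only be set side by side.

Compound 4 `CN(C)CCCNc1nc2cc([N+](=O)[O-])ccc2nc1NCc1cc(F)cc(C(F)(F)F)c1` is the not yet measured analogue of compound 3, carrying (3-fluoro-5-(trifluoromethyl)phenyl in place of 4-fluorophenyl on a saturated chain carbon bound to a nitrogen on an aromatic ring). Among the compounds with values here, the one measured step, an at least 20-fold higher number from compound 1 to compound 2 (1.32 log units; beyond the scatter), changes the group on the aromatic carbon, not the benzyl ring, so it does not bear on this change. Within the data shown here, no measured step touches the ring that is replaced here, so a step of no size beyond the scatter is expected, a 1.1-fold lower number from compound 3 to compound 4 (0.05 log units; within the scatter). Compound 4 is therefore estimated at 3.8 ug/mL, between 1.5 ug/mL and 9.5 ug/mL.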

Compound 4, half-maximal inhibitory concentration: 2.67 ug/mL
Compound 4: the middle estimate sits 1.4-fold (0.15 log units) above what was measured; the range from low to high includes it.
By their numbers in this assay, from the lowest: compounds 4 and 3 (each within the scatter of the next); then compound 1. At a limit, above all of these: compound 2.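

Within the data shown here, this is the first measured change to the ring on a saturated chain carbon bound to a nitrogen on an aromatic ring, and in this assay putting 3-fluoro-5-(trifluoromethyl)phenyl in place of 4-fluorophenyl gives a 1.6-fold lower number from compound 3 to compound 4 (0.20 log units; within the scatter) and so no difference that can be told from scatter. Among these compounds, the entering group has 11 heavy atoms and 4 fluorine against 7 heavy atoms and 1 fluorine in the group it replaces, yet the two values stay within the scatter of each other, so this position accepts that exchange with no measurable step here. Nothing measured here gives a reason for this result.

Going by these compounds, whether a ring carrying an amine or a carboxylic acid would give a step beyond the scatter stays open. Also open, on these data alone, is whether the same exchange would give a similar step with the (3-(4-methylpiperazin-1-yl)propyl)amino group of compound 1 on the shared core.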